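A few compounds are considered here, and "the series" means these few. Any claim that something is new, unique, unknown or untested is made for them only; others in the source may bear on it.

Measured compounds in a functional assay on HEK293 cells (Homo sapiens), read by cAMP accumulation; on this read-out lower numbers stand for stronger inhibition and higher numbers for weaker inhibition:
compound 1 `CCCn1ccnc1-c1cccc(Cl)c1CCc1cc(Br)ccc1OC`, 1900 nM
compound 2 `COc1ccc(Br)cc1CCc1c(Cl)cccc1-c1ncc2n1CCC2`, 710 nM
compound 3 `COc1ccc(Br)cc1CCc1c(Cl)cccc1-c1ncc2n1CCCC2`, 590 nM

Compound 2 stands second highest of the three numbers; its nearest neighbour is compound 3, with a 1.2-fold lower number from compound 2 to compound 3 (0.08 log units; within the scatter), and the furthest is compound 1, with a 2.7-fold lower number from compound 1 to compound 2 (0.43 log units; beyond the scatter) in the other direction. Compound 4 `COc1ccc(Br)cc1CCc1c(F)cccc1-c1ncc2n1CCC2` is not yet measured; it differs from compound 2 by fluoro in place of chloro on an aromatic carbon. Within the data shown here, none of the measured steps bears on this change: all three, including a 3.2-fold lower number from compound 1 to compound 3 (0.51 log units; beyond the scatter), alter the group on the other aromatic ring, and the chloro is kept throughout. Among the measured compounds shown here, with no precedent, the step from compound 2 to compound 4 in this assay is expected to be small, a 1.4-fold higher number from compound 2 to compound 4 (0.15 log units; within the scatter), most likely within the scatter. Compound 4 is therefore estimated at 1000 nM, range 350 nM to 3000 nM.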

Compound 4, half-maximal inhibitory concentration: 390 nM
For compound 4 the middle estimate is 2.6-fold (0.41 log units) above the measured one, and the stated range covers the measured number.
By their numbers in this assay, from the lowest: compounds 4, 3 and 2 (each within the scatter of the next); then compound 1.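

Fluoro in place of chloro, on an aromatic carbon ortho to a large group, is the first change at this position read in this assay, giving a 1.8-fold lower number from compound 2 to compound 4 (0.26 log units; within the scatter). On this single pair, the position accepts either halogen with no readable difference. Nothing measured here bears on the reason for the size of this step.

Open, going by these compounds, is whether a methyl, a methoxy or a nitrile at this position would read the same. Also open, on these data alone, is whether fluoro behaves alike alongside the groups of compound 1 and compound 3.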